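Ethyl on the amine of compound 2: expected effect

The source may report more compounds than this note shows. Statements on the series, on what has been measured and on what is new or still open speak of the compounds shown alone.

Measured so far:
- compound 1, `CCCCCCc1cncc(OC[C@@H]2CCCN2C)c1`: 0.32 nM
- compound 2, `CN1CCC[C@H]1COc1cncc(N)c1`: 0.63 nM

Both compounds share one core and differ only at a single aromatic carbon, where compound 1 carries hexyl and compound 2 carries amino. In an assay on membranes from brain for displacement of a labelled ligand from Neuronal acetylcholine receptor; alpha4/beta2 (Rattus norvegicus) (a higher number here means a weaker inhibitor, a lower number a stronger inhibitor), compound 1 gives 0.32 nM and compound 2 gives 0.63 nM; the step of a 2.0-fold higher number from compound 1 to compound 2 (0.29 log units; within the scatter) is within the scatter, so the two numbers cannot be told apart. Compound 2 holds the higher of the two numbers, but only by a margin the assay cannot resolve.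

Compound 3, `CCNc1cncc(OC[C@@H]2CCCN2C)c1`, grows out of compound 2 by ethyl in place of hydrogen on a nitrogen on an aromatic ring. Within the data shown here, no measured step touches this nitrogen, so the only guidance is that exchanging the whole hexyl for amino changed little in this assay. For compound 3 a step of a 1.1-fold lower number from compound 2 to compound 3 (0.02 log units; within the scatter) is therefore expected, that is, nothing beyond the scatter, and compound 3 is estimated at 0.6 nM (range 0.2 nM to 2 nM).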

Compound 3, inhibition constant: 3.7 nM
Beside the measured number, compound 3's estimate is 6.2-fold (0.79 log units) below it, and the stated range ends below it.
By their numbers in this assay, from the lowest: compounds 1 and 2 (each within the scatter of the next); then compound 3.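

In this assay this nitrogen proves sensitive to what it carries: ethyl in place of hydrogen produces a 5.9-fold higher number from compound 2 to compound 3 (0.77 log units; beyond the scatter) and so moves the number beyond the scatter. Ethylamino in place of hexyl on the same aromatic carbon produces a 12-fold higher number from compound 1 to compound 3 (1.06 log units; beyond the scatter) and so shows that the number does not simply follow the size of the group here, since hexyl and amino could not be told apart while ethylamino stands apart from both. No measurement on hand explains why the ethyl has this effect.

On these data alone, it remains open whether the smaller methyl on this nitrogen would give a step of its own, or whether a longer chain such as propyl would raise the number further. The effect of a second ethyl on the same nitrogen, or of an acetyl group in place of the ethyl, is also unknown.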